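The source may report more compounds than this note shows. Statements on the series, on what has been measured and on what is new or still open speak of the compounds shown alone.

Compound 1, `COc1ccc2c(/C=C/C(=O)c3cc(OC)c(OC)c(SC)c3)c[nH]c2c1`: 112 nM
Compound 2, `COc1ccc2c(/C=C/C(=O)c3cc(OC)c(OC)c(SC)c3)cn(C)c2c1`: 122 nM
Compound 3, `COc1cc(C(=O)/C=C/c2cn(C)c3ccccc23)cc(N)c1OC`: 289 nM

All three compounds were tested in a functional assay on MHCC97H cells (Homo sapiens) for antiproliferative activity, read by MTT assay, with a stated time of 48 h; a lower number here means a stronger inhibitor, a higher number a weaker inhibitor. Compound 2 and compound 1 share one core and differ only in one place: hydrogen in place of methyl on an aromatic nitrogen. That step, a 1.1-fold lower number from compound 2 to compound 1 (0.04 log units; within the scatter), is small and lies within the scatter, so the two values are read as alike. Compound 3 carries a different core; the difference between the two cores is not broken down here. What the values show is that compound 3 gives a higher number than compound 2 and compound 1, and those gaps lie beyond the scatter.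

Compound 4, `COc1cc(C(=O)/C=C/c2c[nH]c3ccccc23)cc(N)c1OC`, has not yet been measured. It comes from compound 3 by the same change that leads from compound 2 to compound 1: hydrogen in place of methyl on an aromatic nitrogen. Because that earlier step, a 1.1-fold lower number from compound 2 to compound 1 (0.04 log units; within the scatter), stayed within the scatter, the step from compound 3 to compound 4 is expected to be similar in size, a 1.1-fold lower number from compound 3 to compound 4 (0.03 log units; within the scatter). This rests on a single pair, so it remains an expectation. Compound 4 is therefore estimated at 270 nM, most likely between 150 nM and 500 nM.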

Compound 4, half-maximal inhibitory concentration: 263 nM
Compound 4: middle estimate off by 1.0-fold (0.01 log units), on the high side; low and high end bracket the measured number.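

In this assay, putting hydrogen in place of methyl on the aromatic nitrogen of the core of compound 3 gives a small step, a 1.1-fold lower number from compound 3 to compound 4 (0.04 log units; within the scatter). Set beside the same change on the other core, the two steps agree: the same change on two cores in this assay, a 1.1-fold lower number (0.04 log units; within the scatter) from compound 2 to compound 1 and a 1.1-fold lower number (0.04 log units; within the scatter) from compound 3 to compound 4, 1.0-fold (0.00 log units) apart, within the scatter of two such steps This shows that, on these two cores and in this one cell assay, the methyl and the hydrogen on that nitrogen give values read as alike, so the step carried over from one core to the other; it does not show that the same would hold on a further core or in another kind of assay, and it does not explain why the change has so little effect.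

The compounds shown carry only hydrogen or methyl on that nitrogen. A longer chain there, such as a propyl group, or a chain ending in an amine or a carboxylic acid, could behave differently, and that remains an open question.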